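This account rests on a few compounds, and the source may have more. Where it says the series, first, only, none or still open, it means among the compounds named here.

Three members of this series share the same core and differ only in the chain and in the aromatic ring hung on the hydrazone. Compound 1 `O=C(CCc1nc2ccccc2c(=O)[nH]1)N/N=C/c1ccc(Cl)cc1` gives 381000000 nM in a physicochemical assay, read by spectrophotometry, with a stated time of 30 min (a lower number here means a stronger inhibitor, a higher number a weaker inhibitor), compound 2 `O=C(CCCc1nc2ccccc2c(=O)[nH]1)N/N=C/c1ccc(Cl)cc1` gives 353000000 nM, and compound 3 `COc1cc(/C=N/NC(=O)CCc2nc3ccccc3c(=O)[nH]2)cc(OC)c1OC` gives 85000000 nM. Compound 2 thus stands second highest of the three numbers; its gap to compound 1 lies within the usual scatter, while compound 3 sits clearly lower, beyond that scatter.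

The next compound to consider is compound 4 `O=C(CCCc1nc2ccccc2c(=O)[nH]1)N/N=C/c1ccc(O)c(O)c1`. It differs from compound 2 in one place: 3,4-dihydroxyphenyl in place of 4-chlorophenyl on a carbon with a double bond to nitrogen. Within the data shown here, no pair of measured compounds shows this particular change, so the size of the step can only be guessed from what the three numbers suggest. Since compound 3, whose aromatic ring carries oxygen substituents, gives 85000000 nM, a moderate lowering in this assay seems the more likely direction, though a result within the scatter would not surprise. Compound 4 is therefore expected to give about 150000000 nM, between 50000000 nM and 450000000 nM, an estimated step of a 2.4-fold lower number from compound 2 to compound 4 (0.37 log units; beyond the scatter).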

Compound 4, half-maximal inhibitory concentration: 95000000 nM
The estimate for compound 4 lay 1.6-fold (0.20 log units) above the measured number; measured number inside the range.
By their numbers in this assay, from the lowest: compounds 3 and 4 (each within the scatter of the next); then compounds 2 and 1 (each within the scatter of the next).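

Measured in this assay the change of 4-chlorophenyl to 3,4-dihydroxyphenyl on a carbon with a double bond to nitrogen gives a 3.7-fold lower number from compound 2 to compound 4 (0.57 log units; beyond the scatter) and so moves the number by more than the scatter. Among these compounds, this is the first step in which only one place differs, so it shows that the aromatic ring at this position can shift the number by itself while the chain stays the same. No measurement at hand explains why the number falls with this change.

Going by these compounds, the step removes the chlorine and adds both hydroxyl groups at once, so it remains open whether a plain phenyl or a 4-hydroxyphenyl would read closer to compound 2 or to compound 4. Also open, on these data alone, is how an amine or a carboxylic acid would read on this ring, and whether the same change holds on the chain of compound 1.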